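Swapping a furan ring for a hydroxyphenyl ring

A few compounds are considered here, and "the series" means these few. Any claim that something is new, unique, unknown or untested is made for them only; others in the source may bear on it.

In a functional assay on A549 cells (Homo sapiens) for antiproliferative activity, read by MTT assay (a lower number here means a stronger inhibitor, a higher number a weaker inhibitor), compound 3 `Cn1c(=O)c(=O)n(C2CCCC2)c2nc(N/N=C/c3ccco3)ncc21` gives only a limit, > 100000 nM, and not a number. Compound 4 `Cn1c(=O)c(=O)n(C2CCCC2)c2nc(N/N=C/c3cccc(O)c3)ncc21` differs from it in one place: 3-hydroxyphenyl in place of furan-2-yl on a carbon with a double bond to nitrogen. Two measured relatives carry other phenyl groups there. Compound 1 `Cn1c(=O)c(=O)n(C2CCCC2)c2nc(N/N=C/c3ccc(O)c(F)c3)ncc21`, with 3-fluoro-4-hydroxyphenyl, gives 97800 nM, and compound 2 `Cn1c(=O)c(=O)n(C2CCCC2)c2nc(N/N=C/c3ccc(C(F)(F)F)cc3)ncc21`, with 4-(trifluoromethyl)phenyl, gives 40600 nM. Those two differ by a 2.4-fold lower number from compound 1 to compound 2 (0.38 log units; beyond the scatter). The nearest guide is the hydroxyphenyl of compound 1, and the step there is an at least 1.0-fold higher number from compound 1 to compound 3 (0.00 log units; that floor lies within the scatter). The larger step, an at least 2.4-fold higher number from compound 2 to compound 3 (0.39 log units; beyond the scatter), involves a trifluoromethyl group that compound 4 lacks. Only a small drop, perhaps none beyond the scatter, is therefore expected, namely an at least 1.2-fold lower number from compound 3 to compound 4 (0.09 log units; that floor lies within the scatter). The estimated value for compound 4 is 80000 nM, within a range of 40000 nM to 120000 nM.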

Compound 4, half-maximal inhibitory concentration: > 100000 nM
Compound 4 gave a limit, no number (the forecaster's own chance of this, stated with the estimate: 40%); middle value at least 1.2-fold (0.09 log units) from the limit.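

In this assay compound 4 gives only a limit and not a number, as does compound 3, so the step between them cannot be read: the limit of > 100000 nM in this assay, at which 2 of the 4 values shown sit.

Even so, the 4-(trifluoromethyl)phenyl group keeps its edge over a second ring, 3-hydroxyphenyl, with an at least 2.4-fold higher number from compound 2 to compound 4 (0.39 log units; beyond the scatter). The comparison with 3-fluoro-4-hydroxyphenyl settles nothing, with an at least 1.0-fold higher number from compound 1 to compound 4 (0.00 log units; that floor lies within the scatter).

As far as these compounds go, how 3-hydroxyphenyl and furan-2-yl truly rank remains open. So does whether a phenyl ring bearing an amine or a carboxylic acid at this place would give a clear number.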